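Swapping the Pyridine for a Cyano-Methyl Phenyl Ring

The source may hold more compounds than are shown below. What is called first, only, known or untested is meant among the compounds shown, and "the series" means these compounds.

Compound 1, `COc1cc(-c2c(C)nn(-c3nc(-c4ccc(Cl)c(Cl)c4)c(SC(C)C)s3)c2C(=O)O)cc(C(F)(F)F)c1`, gives 1380 nM in a functional assay on BJAB cells (Homo sapiens) for antiproliferative activity, with a stated time of 4 days; a higher number here means that more compound is needed for the effect, a lower number that less compound is needed.
Compound 2, `Cc1nn(-c2nc(-c3ccc(Cl)c(Cl)c3)c(SC(C)C)s2)c(C(=O)O)c1-c1cnn(C)c1`, gives 6800 nM in this assay.
Compound 3, `COc1cncc(-c2c(C)nn(-c3nc(-c4ccc(Cl)c(Cl)c4)c(SC(C)C)s3)c2C(=O)O)c1`, gives 21000 nM in this assay.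

Compound 3 stands at the highest number of the three in this assay: its nearest neighbour is compound 2, a step of a 3.1-fold higher number from compound 2 to compound 3 (0.49 log units; beyond the scatter), and the furthest is compound 1, a step of a 15-fold higher number from compound 1 to compound 3 (1.18 log units; beyond the scatter). Both of these steps lie beyond the usual scatter, so compound 3 needs the most material of the set to reach the effect.

Compound 4, `Cc1cc(C#N)cc(-c2c(C)nn(-c3nc(-c4ccc(Cl)c(Cl)c4)c(SC(C)C)s3)c2C(=O)O)c1`, is not yet measured. It differs from compound 3 in one place: 3-cyano-5-methylphenyl in place of 5-methoxypyridin-3-yl on an aromatic carbon. The entering group is, like the 3-methoxy-5-(trifluoromethyl)phenyl of compound 1, a six-membered aromatic ring of carbon only, whereas compound 3 carries a ring with one hetero atom. The step that bears most on this change is a 15-fold higher number from compound 1 to compound 3 (1.18 log units; beyond the scatter), a large rise when the carbon-only ring was replaced by the pyridine; going back to a carbon-only ring, with different substituents, is expected to undo part of that rise. A step of an 8.4-fold lower number from compound 3 to compound 4 (0.92 log units; beyond the scatter) is therefore expected in this assay, toward a lower number. For compound 4 the estimated value is 2500 nM, with a range from 800 nM to 8000 nM.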

Compound 4, half-maximal effective concentration: 4800 nM
Estimate against measurement, compound 4: 1.9-fold (0.28 log units) below; the measured number falls inside the stated range.
By their numbers in this assay, from the lowest: compound 1; then compounds 4 and 2 (each within the scatter of the next); then compound 3.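

Placing a carbon-only ring on this aromatic carbon in place of the 5-methoxypyridin-3-yl lowers the number in this assay, with a 4.4-fold lower number from compound 3 to compound 4 (0.64 log units; beyond the scatter), but a carbon-only ring does not by itself restore the level of compound 1, as a 3.5-fold higher number from compound 1 to compound 4 (0.54 log units; beyond the scatter) shows, so the substituents on the ring matter as well as the ring atoms. Ring type alone also fails to sort these compounds: the five-membered 1-methyl-1H-pyrazol-4-yl and the six-membered 3-cyano-5-methylphenyl cannot be told apart here, with a 1.4-fold lower number from compound 2 to compound 4 (0.15 log units; within the scatter), and compound 2 therefore goes against any simple rule that carbon-only rings give the lower numbers. No measurement at hand accounts for any of these steps.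

Compound 1 and compound 4 differ in both ring substituents at once, and the compounds shown cannot separate the share of the methoxy and trifluoromethyl groups from that of the methyl and nitrile groups. Also open, going by these compounds, is where a plain phenyl ring, or a phenyl ring carrying an amine or a second carboxylic acid, would fall in this assay.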